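This account rests on a few compounds, and the source may have more. Where it says the series, first, only, none or still open, it means among the compounds named here.

Measured in a functional assay on L1210 cells (Mus musculus) for antiproliferative activity, read by cell counting, with a stated time of 96 h; on this read-out higher numbers stand for weaker inhibition and lower numbers for stronger inhibition:
- Compound 1 `CC(=O)c1ccc(Oc2ccccc2NC(C)=C2C(=O)CC(c3ccccc3)CC2=O)cc1`: 190 nM
- Compound 2 `CC(Nc1ccccc1Oc1ccccc1)=C1C(=O)CC(c2ccccc2)CC1=O`: 86 nM
- Compound 3 `CCOc1ccccc1NC(C)=C1C(=O)CC(c2ccccc2)CC1=O`: 190 nM

Compound 3, at 190 nM, is level with compound 1, and together they hold the highest number of the three. Compound 4 `CC(Nc1ccccc1Oc1cccc(N)c1)=C1C(=O)CC(c2ccccc2)CC1=O` has 3-aminophenyl in place of ethyl on an oxygen on an aromatic ring.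

Two measured steps swap the same two kinds of group, though in the opposite direction. Putting ethyl in place of phenyl gave a 2.2-fold higher number from compound 2 to compound 3 (0.34 log units; beyond the scatter). Putting ethyl in place of 4-acetylphenyl gave no change at the digits printed from compound 1 to compound 3 (within the scatter). Changes on that ring also count, since losing the acetyl gave a 2.2-fold lower number from compound 1 to compound 2 (0.34 log units; beyond the scatter). Within the data shown here, no measured compound carries an amino group, so its contribution is unknown. Compound 4 should therefore fall among the ring-bearing compounds, with a small shift toward a lower number or none beyond the scatter expected in this assay.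

The expected change is a 1.7-fold lower number from compound 3 to compound 4 (0.24 log units; within the scatter).

The estimate for compound 4 is 110 nM, with an expected range of 45 nM to 270 nM.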

Compound 4, half-maximal inhibitory concentration: 53 nM
Beside the measured number, compound 4's estimate is 2.1-fold (0.32 log units) above it; measured number inside the range.
By their numbers in this assay, from the lowest: compounds 4 and 2 (each within the scatter of the next); then compounds 1 and 3 (each within the scatter of the next).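

In this assay, 3-aminophenyl in place of ethyl on the oxygen gave a 3.6-fold lower number from compound 3 to compound 4 (0.55 log units; beyond the scatter), so an aromatic ring at this position can give a stronger result than ethyl even when it carries a substituent. Compound 1 had not shown this, since its 4-acetylphenyl only matched ethyl, whereas 3-aminophenyl in place of 4-acetylphenyl gave a 3.6-fold lower number from compound 1 to compound 4 (0.55 log units; beyond the scatter). The amino group itself shows no clear effect, as amino in place of hydrogen gave a 1.6-fold lower number from compound 2 to compound 4 (0.21 log units; within the scatter), which leaves compound 2 and compound 4 unranked.

On these data alone, whether a hydroxyl, a methoxy or a carboxylic acid on the same ring would keep or lose this level remains open. Nothing available explains any of these steps.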